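Swapping 4-nitrophenyl for 6-methoxypyridin-3-yl on the shared core

A few compounds are considered here, and "the series" means these few. Any claim that something is new, unique, unknown or untested is made for them only; others in the source may bear on it.

For the measured compounds named here, in a functional assay on K562 cells (Homo sapiens) for antiproliferative activity, read by MTT assay, with a stated time of 24 h (on this read-out higher numbers stand for weaker inhibition and lower numbers for stronger inhibition), compound 3 `COc1ccc(C(=O)/C=C/c2ccc([N+](=O)[O-])cc2)c2c1C=CC(C)(C)O2` gives 7770 nM, the only true number among the compounds tested so far. Compound 1 `COc1cccc(/C=C/C(=O)c2ccc(OC)c3c2OC(C)(C)C=C3)c1` returns only a limit of the assay, > 10000 nM. Compound 2 `COc1ccc(/C=C/C(=O)c2ccc(OC)c3c2OC(C)(C)C=C3)c(F)c1` also returns only a limit, > 10000 nM.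

The next compound, compound 4 `COc1ccc(/C=C/C(=O)c2ccc(OC)c3c2OC(C)(C)C=C3)cn1`, has 6-methoxypyridin-3-yl in place of the 4-nitrophenyl of compound 3, on a double-bonded chain carbon bound to a double-bonded chain carbon: 6-methoxypyridin-3-yl in place of 4-nitrophenyl on a double-bonded chain carbon bound to a double-bonded chain carbon. Going by the values given here, two measured steps bear on this change, an at least 1.2-fold lower number from compound 1 to compound 3 (0.10 log units; that floor lies within the scatter) and an at least 1.2-fold lower number from compound 2 to compound 3 (0.10 log units; that floor lies within the scatter), and both floors lie within the scatter. Those steps removed a methoxy-bearing ring, whereas compound 4 carries a methoxy group again, so a small move to a higher number is expected in this assay, not clearly beyond the scatter. The expected change is a 1.4-fold higher number from compound 3 to compound 4 (0.15 log units; within the scatter). For compound 4 the estimated value is 11000 nM, with an expected range of 4500 nM to 30000 nM, and the assay may well report only a limit.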

Compound 4, half-maximal inhibitory concentration: > 10000 nM
Compound 4 gave a limit, no number (the forecaster's own chance of this, stated with the estimate: 60%); the middle value does not contradict the limit.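

In this assay, putting 6-methoxypyridin-3-yl in place of 4-nitrophenyl gives an at least 1.2-fold higher number from compound 3 to compound 4 (0.10 log units; that floor lies within the scatter), so the floor of this change does not clear the scatter. For the compounds shown here, this is the first ring with a hetero atom seen on a double-bonded chain carbon bound to a double-bonded chain carbon, and its result for compound 4 is only a limit, not a number. The steps from compound 1 and from compound 2 to compound 4 cannot be read, and compound 3 remains the only compound with a true number, the others sharing one limit: the limit of > 10000 nM in this assay, at which 3 of the 4 values shown sit.

Going by these compounds, whether 4-nitrophenyl offers any real gain at this place remains open, and no readable step involving compound 3 clearly passes the scatter. Also open, on these data alone, is how a 4-aminophenyl or 4-carboxyphenyl group would read at this place on the shared core.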